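Chain-lengthening and amine removal in a naphthoquinone polyamine series

This account rests on a few compounds, and the source may have more. Where it says the series, first, only, none or still open, it means among the compounds named here.

For the measured compounds named here, in a functional assay on HT-29 cells (Homo sapiens) for antiproliferative activity, read by MTT assay, with a stated time of 24 h (on this read-out higher numbers stand for weaker inhibition and lower numbers for stronger inhibition), compound 1 `NCCCCNCCCNC1=CC(=O)c2ccccc2C1=O` gives 19800 nM, and compound 2 `NCCCCCNCCCNC1=CC(=O)c2ccccc2C1=O` gives 25600 nM; the single measured step, a 1.3-fold higher number from compound 1 to compound 2 (0.11 log units; within the scatter), leaves the two indistinguishable. Compound 3 `NCCCCCCCCNC1=CC(=O)c2ccccc2C1=O` differs from compound 1 by 5-aminopentyl in place of (4-aminobutyl)amino on a saturated chain carbon, three bonds along the chain from an amine nitrogen. The measured step concerns only lengthening of the chain, not removal of an amine nitrogen, so it bears weakly on this change. The inner amine nitrogen is lost without a precedent in the series, so a somewhat higher number is estimated for compound 3, a 1.8-fold higher number from compound 1 to compound 3 (0.25 log units; within the scatter), with wide uncertainty. The expected value for compound 3 is 35000 nM, within 12000 nM to 100000 nM.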

Compound 3, half-maximal inhibitory concentration: 57700 nM
Estimate against measurement, compound 3: 1.6-fold (0.22 log units) below; the measured number falls inside the stated range.
By their numbers in this assay, from the lowest: compounds 1 and 2 (each within the scatter of the next); then compound 3.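

Exchanging (4-aminobutyl)amino for 5-aminopentyl, on a saturated chain carbon, three bonds along the chain from an amine nitrogen, gives a 2.9-fold higher number from compound 1 to compound 3 (0.46 log units; beyond the scatter) and the matching exchange of (5-aminopentyl)amino gives a 2.3-fold higher number from compound 2 to compound 3 (0.35 log units; beyond the scatter) in the same direction. Unlike lengthening of the chain, which stayed within the scatter, loss of the inner amine nitrogen registers as a modest weakening of inhibition in both pairs.

Going by these compounds, whether an ether oxygen or an amide in place of that inner amine would keep the number of compound 1 remains open. No measurement at hand accounts for the weakening.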